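Working notes on the side chain of compound 2

The compounds below may be only part of what the source reports. "The series", "measured", "known", "first", "only" and "open" are said of these compounds alone.

Compound 1 `COC(=O)Cn1c(=O)c(C)cn([C@@H]2O[C@H](CO[Si](C)(C)C(C)(C)C)[C@@]3(OS(=O)(=O)C=C3N)[C@H]2O[Si](C)(C)C(C)(C)C)c1=O`, compound 2 `Cc1cn([C@@H]2O[C@H](CO[Si](C)(C)C(C)(C)C)[C@@]3(OS(=O)(=O)C=C3N)[C@H]2O[Si](C)(C)C(C)(C)C)c(=O)n(CC(=O)O)c1=O` and compound 3 `Cc1cn([C@@H]2O[C@H](CO[Si](C)(C)C(C)(C)C)[C@@]3(OS(=O)(=O)C=C3N)[C@H]2O[Si](C)(C)C(C)(C)C)c(=O)n(CCCN2C(=O)c3ccccc3C2=O)c1=O` share one core and differ only in the chain on the aromatic nitrogen. In a functional assay on CCRF-CEM cells (Homo sapiens) (a lower number here means that less compound is tolerated, a higher number that more compound is tolerated), compound 1 gives only a limit, > 152000 nM. In this assay compound 2 gives 152000 nM. Compound 3 likewise reaches only a limit, > 250000 nM. Going by the values given here, the single measured step, a number no higher from compound 1 to compound 2 (the limit leaves the size open), is hydrogen in place of methyl on an oxygen next to a carbonyl group, and its size stays open. Among the compounds with values here, compound 2 thus holds the only number among the three values, the other two being limits (the limit of > 152000 nM in this assay, at which 1 of the 3 values shown sits, (the limit of > 250000 nM in this assay, at which 1 of the 3 values shown sits)).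

Compound 4 `Cc1cn([C@@H]2O[C@H](CO[Si](C)(C)C(C)(C)C)[C@@]3(OS(=O)(=O)C=C3N)[C@H]2O[Si](C)(C)C(C)(C)C)c(=O)n(CCCN(C)C)c1=O` is still to be measured. Its change from compound 2 is 2-(dimethylamino)ethyl in place of carboxy on a saturated chain carbon bound to an aromatic nitrogen. Within the data shown here, no measured step covers an exchange of this kind, and the one step that exists yields no readable size, so nothing points to a move beyond the scatter in either direction, up or down. Compound 4 is therefore expected close to the value of compound 2, at 150000 nM, with a range from 50000 nM to 400000 nM. The step this implies, a 1.0-fold lower number from compound 2 to compound 4 (0.01 log units; within the scatter), is expected to lie within the scatter, with a fair chance that only a limit is reported.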

Compound 4, half-maximal cytotoxic concentration: 10400 nM
For compound 4 the middle estimate is 14-fold (1.16 log units) above the measured one; the measured number lies below the stated range.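

In this assay, the chain on the aromatic nitrogen now proves able to shift the number well beyond the scatter: 2-(dimethylamino)ethyl in place of carboxy on a saturated chain carbon bound to an aromatic nitrogen gives a 15-fold lower number from compound 2 to compound 4 (1.16 log units; beyond the scatter), the first readable size of a step at this position. The same exchange against methoxycarbonyl gives an at least 14-fold lower number from compound 1 to compound 4 (1.16 log units; beyond the scatter), and the shorter dimethylamino end in place of the larger group of 11 heavy atoms gives an at least 24-fold lower number from compound 3 to compound 4 (1.38 log units; beyond the scatter), so that compound 4 carries the lowest number of the four, although these two steps each start from a limit of the assay. Nothing measured here gives a reason for these steps.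

As far as these compounds go, it remains open whether the step follows the dimethylamino end or the length of the chain, which a primary amine on the same 3-carbon chain, or the dimethylamino group on a longer chain, would help to separate. A carboxylic acid on a longer chain would likewise show whether the chain length alone moves the number.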